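Ethoxycarbonyl to thiophen-2-yl on the triazole: expected shift

The source may report more compounds than this note shows. Statements on the series, on what has been measured and on what is new or still open speak of the compounds shown alone.

Measured so far in a functional assay on A549 cells (Homo sapiens) for cytotoxicity, read by MTT assay, with a stated time of 72 h; a higher number here means that more compound is needed for the effect, a lower number that less compound is needed:
- compound 1 `CCS[C@@H]1[C@H](SCC)[C@@H](Cn2cc(-c3ccccc3C(F)(F)F)nn2)O[C@H]1n1ccc(=O)[nH]c1=O`: 19400 nM
- compound 2 `CCOC(=O)c1cn(C[C@H]2O[C@@H](n3ccc(=O)[nH]c3=O)[C@H](SCC)[C@@H]2SCC)nn1`: >= 100000 nM

Compound 1 gives 19400 nM in this assay. Compound 2 sits at the limit of this assay, >= 100000 nM, so only a limit and no number is known for it (the limit of >= 100000 nM in this assay, at which 1 of the 2 values shown sits). Among the compounds with values here, the single measured step, an at least 5.1-fold higher number from compound 1 to compound 2 (0.71 log units; beyond the scatter), is beyond the scatter: exchanging the 2-(trifluoromethyl)phenyl ring for ethoxycarbonyl raised the number to the limit.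

Compound 3 `CCS[C@@H]1[C@H](SCC)[C@@H](Cn2cc(-c3cccs3)nn2)O[C@H]1n1ccc(=O)[nH]c1=O` differs from compound 2 by thiophen-2-yl in place of ethoxycarbonyl on an aromatic carbon. Within the data shown here, the only step that bears on this change is an at least 5.1-fold higher number from compound 1 to compound 2 (0.71 log units; beyond the scatter), which runs the other way: an aromatic ring at this carbon was replaced by the ester. Compound 3 restores an aromatic ring at the same carbon, though a five-membered one with sulfur rather than the substituted phenyl of compound 1. The expectation is therefore a lower number for compound 3, a step of an at least 3.3-fold lower number from compound 2 to compound 3 (0.52 log units; beyond the scatter), landing near compound 1 rather than at the limit. For compound 3 the estimated value in this assay is 30000 nM, with a range from 10000 nM to 100000 nM.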

Compound 3, half-maximal effective concentration: >= 100000 nM
Compound 3: no number, only a limit (the forecaster's own chance of this, stated with the estimate: 30%); at least 3.3-fold (0.52 log units) between middle value and limit.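

Having an aromatic ring on this aromatic carbon is not enough to give a number in this assay: thiophen-2-yl in place of 2-(trifluoromethyl)phenyl gives an at least 5.1-fold higher number from compound 1 to compound 3 (0.71 log units; beyond the scatter). Compound 2 and compound 3 both give only a limit, so the step between them cannot be read, and ethoxycarbonyl and thiophen-2-yl cannot be ranked against each other. Of the three compounds, only compound 1 gives a number, and the other two share one limit of the assay, which leaves 2-(trifluoromethyl)phenyl as the only group here with a readable effect in this assay: the limit of >= 100000 nM in this assay, at which 2 of the 3 values shown sit.

As far as these compounds go, it remains open whether the number of compound 1 depends on the phenyl ring itself or on its trifluoromethyl group; an unsubstituted phenyl at this carbon, or a phenyl carrying an amine in place of the trifluoromethyl, would separate the two. From the compounds shown here alone, how far compound 2 and compound 3 lie past the limit also stays open, as does whether any other five-membered aromatic ring at this carbon would give a number.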